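Amino Substitution on a Chloropurine Core Across Two Isomers

The source may report more compounds than this note shows. Statements on the series, on what has been measured and on what is new or still open speak of the compounds shown alone.

Compound 1 `ClCc1ccc(Cn2cnc3c(Cl)ncnc32)cc1` gives 6920 nM in a functional assay on EKVX cells (Homo sapiens) for cytotoxicity, read by sulforhodamine B assay, with a stated time of 48 h; a higher number here means a weaker inhibitor of growth, a lower number a stronger inhibitor of growth. Compound 2 `Nc1nc(Cl)c2ncn(Cc3ccc(CCl)cc3)c2n1` differs by amino in place of hydrogen on an aromatic carbon and gives 7240 nM, so the step of a 1.0-fold higher number from compound 1 to compound 2 (0.02 log units; within the scatter). Compound 3 `ClCc1ccccc1Cn1cnc2c(Cl)ncnc21` gives 11000 nM; how its core differs from that of compound 1 is not broken down here, the two simply having the same atoms joined differently. Compound 4 `Nc1nc(Cl)c2ncn(Cc3ccccc3CCl)c2n1` carries the same change relative to compound 3, (amino in place of hydrogen on an aromatic carbon), at a place described in identical words. Because a 1.0-fold higher number from compound 1 to compound 2 (0.02 log units; within the scatter) stayed within the scatter, the step from compound 3 to compound 4 is expected to be similar, a 1.0-fold higher number from compound 3 to compound 4 (0.02 log units; within the scatter). Compound 4 is therefore estimated to give 11500 nM in this assay, with a plausible range from 6000 nM to 22000 nM.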

Compound 4, concentration for total growth inhibition: 30900 nM
For compound 4 the middle estimate is 2.7-fold (0.43 log units) below the measured one; the measured number lies above the stated range.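

In this assay, going by these compounds alone, amino in place of hydrogen on an aromatic carbon gave a clearly weaker inhibitor of growth on only one of the two cores, with a 2.8-fold higher number from compound 3 to compound 4 (0.45 log units; beyond the scatter). The size of the step therefore did not carry over from one core to the other: the same change on two cores in this assay, a 1.0-fold higher number (0.02 log units; within the scatter) from compound 1 to compound 2 and a 2.8-fold higher number (0.45 log units; beyond the scatter) from compound 3 to compound 4, 2.7-fold (0.43 log units) apart, beyond the scatter of two such steps. Within the data shown here, this shows that the outcome of the change depended on the core in these four compounds, but with only one pair of steps it does not show which feature of the cores is responsible or how the change would behave on a further core.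

The compounds shown carry only amino at this place, so it remains open whether a methylamino or methoxy group there would also differ between the two cores. As far as these compounds go, it also remains open whether the gap between the two steps would hold on other cells.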